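The compounds below may be only part of what the source reports. "The series", "measured", "known", "first", "only" and "open" are said of these compounds alone.

Measured compounds:
- compound 1 `N#CC1=C(N)N(c2ccc(S(N)(=O)=O)cc2)C2=C(C(=O)CCC2)C1c1ccc(Cl)cc1Cl` — 95%
- compound 2 `N#CC1=C(NC(=O)C2CC2)N(c2ccc(S(N)(=O)=O)cc2)C2=C(C(=O)CCC2)C1c1ccc(Cl)cc1Cl` — 60%
- compound 3 `N#CC1=C(NC(=O)/C=C/c2ccccc2)N(c2ccc(S(N)(=O)=O)cc2)C2=C(C(=O)CCC2)C1c1ccc(Cl)cc1Cl` — 45%

In a functional assay on Ehrlich cells (Mus musculus) for cytotoxicity, read by trypan blue exclusion, with a stated time of 2 h, tested at 100 ug/mL (on this read-out higher numbers stand for a stronger effect at the one concentration tested and lower numbers for a weaker effect), compound 1 gives 95%, the highest of the three numbers, with compound 2 nearest and compound 3 furthest. Both measured steps from compound 1 are on the amine nitrogen: a number 35 percentage points lower from compound 1 to compound 2 (beyond the scatter) and a number 50 percentage points lower from compound 1 to compound 3 (beyond the scatter). The step between the acylated pair is smaller, a number 15 percentage points lower from compound 2 to compound 3 (beyond the scatter).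

Compound 4 `NC1=C(C(=O)O)C(c2ccc(Cl)cc2Cl)C2=C(CCCC2=O)N1c1ccc(S(N)(=O)=O)cc1` is not yet measured. It differs from compound 1 as follows: carboxy in place of cyano on a double-bonded ring carbon. Within the data shown here, no measured step touches this ring carbon; all three steps change the amine nitrogen, so none of them bears directly on the step from compound 1 to compound 4. Among the measured compounds shown here, the only guidance is that every change made so far to the shared core of compound 1 lowered the read-out, and that the amine next to the changed carbon is kept. The expected step is therefore a downward one of uncertain size, estimated as a number 25 percentage points lower from compound 1 to compound 4 (beyond the scatter). Compound 4 is estimated at 70%, within 40% to 95%.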

Compound 4, a percentage reported as activity, at one concentration (the size of the read-out at that concentration, not a potency): 60%
Compound 4: the middle estimate sits 10 percentage points above what was measured; measured number inside the range.
By their numbers in this assay, from the lowest: compound 3; then compounds 2 and 4 (each within the scatter of the next); then compound 1.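

In this assay the change from cyano to carboxy on the double-bonded ring carbon gives a number 35 percentage points lower from compound 1 to compound 4 (beyond the scatter) while the amino group stays in place. Among these compounds, the read-out of compound 1 therefore depends on this ring carbon as well as on the amine nitrogen, the only site where the earlier compounds showed a step. Nothing at hand explains the drop at this position.

The compounds shown leave open whether the drop reflects the loss of the nitrile or the arrival of the carboxylic acid, since this position carries only those two groups; a methyl ester or a primary amide on the same carbon would separate the two readings. Also open, on these data alone, is how an acylated amine, such as the cyclopropylcarbonyl amide, behaves together with carboxy on this carbon.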